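A few compounds are considered here, and "the series" means these few. Any claim that something is new, unique, unknown or untested is made for them only; others in the source may bear on it.

Measured compounds:
- compound 1, `CC(C(=O)NCc1ccc(C(F)(F)F)nc1NCC1CCN(C(=O)OC(C)(C)C)CC1)c1ccc(NS(C)(=O)=O)c(F)c1`: 19.3 nM in a functional assay on CHO-K1 cells for antagonist activity at transient receptor potential cation channel subfamily V member 1 (Homo sapiens), read by FLIPR; a lower number here means a stronger inhibitor, a higher number a weaker inhibitor
- compound 2, `CC(C(=O)NCc1ccc(C(F)(F)F)nc1Nc1ccc(F)cc1)c1ccc(NS(C)(=O)=O)c(F)c1`: 39.2 nM in this assay

Compound 2 gives the higher of the two numbers in this assay; compound 1 sits at the lower number, and that gap is beyond the scatter. Compound 3, `CCCN(CCC)c1nc(C(F)(F)F)ccc1CNC(=O)C(C)c1ccc(NS(C)(=O)=O)c(F)c1`, has not been measured. It differs from compound 2 in one place: dipropylamino in place of (4-fluorophenyl)amino on an aromatic carbon. No step between measured compounds covers this change, so its size can only be judged from the two numbers shown. Compound 1 carries a non-aromatic, saturated-ring group at the same position and gives the lower number, so a non-aromatic group there is tolerated in this assay. With the donor of compound 2 gone, a small step in either direction, most likely not beyond the scatter, is expected for compound 3: a 1.3-fold higher number from compound 2 to compound 3 (0.11 log units; within the scatter). The estimate for compound 3 in this assay is 50 nM, within 15 nM to 180 nM.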

Compound 3, inhibition constant: 0.2 nM
For compound 3 the middle estimate is 250-fold (2.40 log units) above the measured one; the whole stated range lies above it.
By their numbers in this assay, from the lowest: compound 3; then compound 1; then compound 2.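

At the aromatic carbon next to the ring nitrogen, replacing (4-fluorophenyl)amino with dipropylamino gives a 200-fold lower number from compound 2 to compound 3 (2.29 log units; beyond the scatter) in this assay. The position is therefore far more sensitive than the earlier pair suggested, with compound 1 at 19.3 nM and compound 2 at 39.2 nM, and neither an aromatic ring nor a hydrogen-bond donor on the group is needed for a very low number. No measured evidence accompanies this step, and its origin remains unassigned.

As far as these compounds go, compound 3 loses the ring and the donor and gains the two propyl chains in a single change, so the contribution of each remains open. A propylamino group, a diethylamino group or a piperidine ring at this carbon would help separate these contributions.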